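Methyl in place of nitro in compound 4

The source may hold more compounds than are shown below. What is called first, only, known or untested is meant among the compounds shown, and "the series" means these compounds.

In a physicochemical assay for lipophilicity (on this read-out higher numbers stand for higher lipophilicity and lower numbers for lower lipophilicity), compound 3 `C[C@H]1CC[C@@H]2[C@@H](OC(=O)[C@]23CC(c2cccc([N+](=O)[O-])c2)=NO3)[C@]2(C)C(=O)C=C[C@@]12O` gives 1.37 and sits level with compound 2 `C[C@H]1CC[C@@H]2[C@@H](OC(=O)[C@]23CC(c2ccc([N+](=O)[O-])cc2)=NO3)[C@]2(C)C(=O)C=C[C@@]12O` at 1.37 on the digits shown. Compound 1 `C[C@H]1CC[C@@H]2[C@@H](OC(=O)[C@]23CC(c2ccccc2Br)=NO3)[C@]2(C)C(=O)C=C[C@@]12O` reaches 2.22 and stands clearly higher. Compound 4 `Cc1cccc(C2=NO[C@]3(C2)C(=O)O[C@@H]2[C@H]3CC[C@H](C)[C@]3(O)C=CC(=O)[C@@]23C)c1` has not yet been measured. It differs from compound 3 in one place, with methyl in place of nitro on an aromatic carbon. For the measured compounds named here, no measured step makes that exact change, and no methyl compound has been measured. The closest evidence is a number 0.85 log units lower from compound 1 to compound 3 (beyond the scatter) and the matching a number 0.85 log units lower from compound 1 to compound 2 (beyond the scatter) where a nitrophenyl takes the place of 2-bromophenyl. The step of no change at the digits printed from compound 2 to compound 3 (within the scatter) shows that the two nitro compounds do not part. Reading a number 0.85 log units lower from compound 1 to compound 3 (beyond the scatter) in reverse, a modest rise of similar size is expected in this assay when nitro leaves. The expected step is a number 0.68 log units higher from compound 3 to compound 4 (beyond the scatter) on this reasoning. Compound 4 is estimated at 2.05 with an expected range from 1.7 to 2.4 awaiting measurement.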

Compound 4, partition coefficient: 1.86
Compound 4: middle estimate off by 0.19 log units, on the high side, and the stated range covers the measured number.
By their numbers in this assay, from the lowest: compounds 2 and 3 (each within the scatter of the next); then compound 4; then compound 1.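

In this assay, methyl in place of nitro on this aromatic carbon gives a number 0.49 log units higher from compound 3 to compound 4 (beyond the scatter), the first step measured for this exact change. The 3-methylphenyl group also parts from the 4-nitrophenyl group, with a number 0.49 log units higher from compound 2 to compound 4 (beyond the scatter), but it does not match the 2-bromophenyl group, with a number 0.36 log units lower from compound 1 to compound 4 (beyond the scatter), so the four compounds fall on three levels, the two nitro compounds sharing the lowest. No measurement shown accounts for the size of these steps.

The compounds shown leave open whether methyl in place of nitro on the 4-nitrophenyl group would give a step of the same size. They also leave open where an amine, a carboxylic acid or a longer chain such as propyl on this aromatic carbon would fall in this assay.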